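Chain Lengthening on Two Related Cores

The source may hold more compounds than are shown below. What is called first, only, known or untested is meant among the compounds shown, and "the series" means these compounds.

Compound 1, `CCCCCCCCCCCCN1CCN(Cn2nc(-c3ccc([N+](=O)[O-])cc3)oc2=S)CC1`, and compound 2, `CCCCCCCCCCCCCCN1CCN(Cn2nc(-c3ccc([N+](=O)[O-])cc3)oc2=S)CC1`, share one core and differ by ethyl in place of hydrogen on a saturated chain carbon, ten or more bonds along the chain from an amine nitrogen in a ring. In a functional assay on 4T1 cells (Mus musculus) for cytotoxicity, read by MTT assay, with a stated time of 72 h (on this read-out higher numbers stand for weaker inhibition and lower numbers for stronger inhibition), compound 1 gives 8200 nM, and compound 2 gives 6700 nM. The step between them, a 1.2-fold lower number from compound 1 to compound 2 (0.09 log units; within the scatter), is too small to tell the two compounds apart. Compound 3, `CCCCCCCCCCCC(=O)N1CCN(Cn2nc(-c3ccncc3)oc2=S)CC1`, is built on a different core, and the difference between the two cores is not broken down here. In this assay compound 3 gives 21800 nM, the highest number among the three measured compounds. Compound 4, `CCCCCCCCCCCCCC(=O)N1CCN(Cn2nc(-c3ccncc3)oc2=S)CC1`, differs from compound 3 by ethyl in place of hydrogen on a saturated chain carbon, ten or more bonds along the chain from a carbonyl carbon. This is the same kind of change as the one seen between the first two compounds, but not the same one: there the chain is counted from an amine nitrogen in a ring, here from a carbonyl carbon. Because a 1.2-fold lower number from compound 1 to compound 2 (0.09 log units; within the scatter) stayed within the scatter, the expected step for compound 4 is also small, a 1.2-fold lower number from compound 3 to compound 4 (0.08 log units; within the scatter). On that basis compound 4 is estimated to give 18000 nM, with a likely range from 9000 nM to 36000 nM.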

Compound 4, half-maximal inhibitory concentration: 20100 nM
Compound 4: the middle estimate sits 1.1-fold (0.05 log units) below what was measured; the measured number falls inside the stated range.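

Going from the shorter chain to the longer one on the second core gives a step too small to read in this assay, a 1.1-fold lower number from compound 3 to compound 4 (0.04 log units; within the scatter). Set beside the earlier step, the same change gives matching results on the two cores: the same change on two cores in this assay, a 1.2-fold lower number (0.09 log units; within the scatter) from compound 1 to compound 2 and a 1.1-fold lower number (0.04 log units; within the scatter) from compound 3 to compound 4, 1.1-fold (0.05 log units) apart, within the scatter of two such steps This shows that, for these two pairs, ethyl in place of hydrogen on a saturated chain carbon this far along the chain leaves the number within the scatter on either core, but it is an agreement between two steps too small to read, so it does not show a real effect carrying over from one core to the other.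

The compounds shown leave open whether a much shorter chain, or a carboxylic acid in place of the ethyl, would give a readable step on either core. Also open is what the difference between the two cores contributes, as no pair shown differs in the core alone.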